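Isobutyl for Isopropyl in a Macrophage Growth Assay

The source may report more compounds than this note shows. Statements on the series, on what has been measured and on what is new or still open speak of the compounds shown alone.

Compound 1 `C=CCONC(=O)CN1C(=O)S/C(=C\c2cccc(C(=O)N[C@@H](CC(C)C)C(=O)OC)c2)C1=O`: > 128000 nM
Compound 2 `C=CCONC(=O)CN1C(=O)S/C(=C\c2cccc(C(=O)N[C@H](C(=O)OC)C(C)C)c2)C1=O`: > 128000 nM
Compound 3 `C=CCONC(=O)Cn1ccc(C(=O)N[C@@H](C)C(=O)N[C@H](C(=O)O)C(C)C)c1`: > 128000 nM

All three values come from a functional assay on RAW264.7 cells (Mus musculus) for inhibition, read by microscopy and resazurin assay, with a stated time of 72 h; a lower number here means a stronger inhibitor, a higher number a weaker inhibitor. For compound 1 the value is a limit of the assay, not a number. The value for compound 2 is also a limit. The value for compound 3 is likewise a limit.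

Compound 1 and compound 2 share a core and differ by isobutyl in place of isopropyl on a saturated chain carbon bound to an amide-type nitrogen and a carbonyl carbon. The step that the two limits leave unreadable from compound 2 to compound 1 cannot be read because all three values sit at the limit of > 128000 nM in this assay, at which 3 of the 3 values shown sit. Compound 3 has a different core, and the difference between the two cores is not broken down here.

Compound 4 `C=CCONC(=O)Cn1ccc(C(=O)N[C@@H](C)C(=O)N[C@@H](CC(C)C)C(=O)O)c1` has not yet been measured. For the measured compounds named here, it differs from compound 3 by isobutyl in place of isopropyl on a saturated chain carbon bound to an amide-type nitrogen and a carbonyl carbon, the same change at the same place as the one between compound 2 and compound 1. The expected step that the limit leaves unreadable from compound 3 to compound 4 is estimated to be small, since a step that the two limits leave unreadable from compound 2 to compound 1 gave no readable gain for this change. Compound 4 is therefore expected near 200000 nM, estimated between 50000 nM and 1000000 nM, most likely reported again as a limit.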

Compound 4, half-maximal inhibitory concentration: > 128000 nM
Compound 4 ended at the assay's limit (the forecaster's own chance of this, stated with the estimate: 85%); the middle value lies beyond the limit too.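

In this assay compound 4 gives > 128000 nM, which is a limit of the assay and not a number. The change from isopropyl to isobutyl between compound 3 and compound 4 gives no readable step, because the values sit at one limit: the limit of > 128000 nM in this assay, at which 4 of the 4 values shown sit.

The compounds shown leave open how large an effect, if any, this change has on inhibition.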